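Working notes on the step from compound 1 to compound 3

The source may report more compounds than this note shows. Statements on the series, on what has been measured and on what is new or still open speak of the compounds shown alone.

Measured in a functional assay on HT-29 cells (Homo sapiens) for cytotoxicity, read by MTT assay, with a stated time of 24 h, tested at 0.64 ug/mL; a higher number here means a stronger effect of the compound at the concentration tested, a lower number a weaker effect:
compound 1 `Cn1c(-c2ccc(NC(=O)CSc3nc4ccccc4s3)cc2)nc(-c2ccccc2)c1-c1ccccc1`: 9.8%
compound 2 `Cn1nnnc1SCC(=O)Nc1ccc(-c2nc(-c3ccccc3)c(-c3ccccc3)n2C)cc1`: 38%

Compound 1 holds the lowest of the two numbers in this assay; its nearest neighbour is compound 2, reached by a number 28.2 percentage points higher from compound 1 to compound 2 (beyond the scatter), an exchange of one sulfur-bound heteroaryl for another at the same place. Compound 3 `CN(C)/C=C/N1CCN(CC(=O)Nc2ccc(-c3nc(-c4ccccc4)c(-c4ccccc4)n3C)cc2)CC1` is not yet measured. It departs from compound 1 by 4-(2-(dimethylamino)ethenyl)piperazin-1-yl in place of (1,3-benzothiazol-2-yl)sulfanyl on a saturated chain carbon bound to a carbonyl carbon.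

Among the measured compounds shown here, the only step that bears on this change is a number 28.2 percentage points higher from compound 1 to compound 2 (beyond the scatter), since it alters the same group on the saturated chain carbon bound to the carbonyl carbon; it moved the read-out upward beyond the scatter. The change to compound 3 is larger in kind: the (1,3-benzothiazol-2-yl)sulfanyl group with its two aromatic rings leaves, and a 4-(2-(dimethylamino)ethenyl)piperazin-1-yl group with a single non-aromatic ring enters. Nothing measured shows how such a group behaves in this series. The expectation therefore rests on that one step and is taken as an upward move of similar or smaller size, with wide uncertainty: for compound 3 the step is estimated as a number 15.2 percentage points higher from compound 1 to compound 3 (beyond the scatter). Compound 3 is thus expected to give 25%, within 5% to 55%.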

Compound 3, a percentage reported as activity, at one concentration (the size of the read-out at that concentration, not a potency): 3.1%
For compound 3 the middle estimate is 21.9 percentage points above the measured one; measured number below the stated range.
By their numbers in this assay, from the lowest: compounds 3 and 1 (each within the scatter of the next); then compound 2.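

In this assay, the place on a saturated chain carbon bound to a carbonyl carbon now holds three different groups, and exchanging (1,3-benzothiazol-2-yl)sulfanyl for 4-(2-(dimethylamino)ethenyl)piperazin-1-yl gives a number 6.7 percentage points lower from compound 1 to compound 3 (within the scatter), so these two groups are not told apart here despite their different ring types. The same entering group, set against (1-methyl-1H-tetrazol-5-yl)sulfanyl, gives a number 34.9 percentage points lower from compound 2 to compound 3 (beyond the scatter), which leaves compound 2 standing apart from both other compounds and shows that the upward step seen earlier does not extend to every replacement at this place. Nothing available explains the separation of compound 2 from compound 1 and compound 3.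

The compounds shown leave open whether the higher read-out of compound 2 follows from the tetrazole ring itself or from that ring joined through sulfur, a question that a (1-methyl-1H-imidazol-2-yl)sulfanyl group or a directly attached tetrazolyl group would address. They also leave open whether the ethenyl part of the entering group matters, as a plain 4-methylpiperazin-1-yl or a morpholin-4-yl group at the same place would show.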